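The compounds below may be only part of what the source reports. "The series", "measured", "known", "first", "only" and "open" are said of these compounds alone.

Four compounds share one core and differ only in the group on an amide-type nitrogen near the end of the chain. Compound 1 `CC[C@H](C)[C@H](NC(=O)c1cccc(Cn2ccnc2)c1)C(=O)NNS(=O)(=O)c1c(C)cc(C)cc1C` carries a sulfonyl with 2,4,6-trimethylphenyl, compound 3 `CC[C@H](C)[C@H](NC(=O)c1cccc(Cn2ccnc2)c1)C(=O)NNS(=O)(=O)c1ccc(OC)cc1` a sulfonyl with 4-methoxyphenyl, and compound 2 `CC[C@H](C)[C@H](NC(=O)c1cccc(Cn2ccnc2)c1)C(=O)NNC(=O)OC(C)(C)C` a (tert-butoxycarbonyl)amino group. In an assay on HEK293 cells for displacement of a labelled ligand from Type-2 angiotensin II receptor (Homo sapiens), tested at 10 uM (on this read-out lower numbers stand for a weaker effect and higher numbers for a stronger effect at the one concentration tested), compound 1 gives 27% and compound 3 gives 20%, and the step of a number 7 percentage points lower from compound 1 to compound 3 (within the scatter) shows that swapping the ring on the sulfonyl sulfur leaves the read-out essentially where it was. In this assay, from the compounds shown here alone, compound 2 gives "not determined" (no result reported), so its own standing is unknown. Compound 4 `CC[C@H](C)[C@H](NC(=O)c1cccc(Cn2ccnc2)c1)C(=O)NO` arises from compound 2 through the change (hydroxy in place of (tert-butoxycarbonyl)amino on an amide-type nitrogen). Among the measured compounds shown here, no measured step touches the amide-type nitrogen itself; the only step at hand concerns the sulfonyl ring and stayed within the scatter, so it gives no direction for this change. The expectation for compound 4 therefore rests only on the general level seen for compound 1 and compound 3, with wide uncertainty. Compound 4 is estimated to give 20% in this assay, expected to fall between 0% and 45%.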

Compound 4, a percentage reported as inhibition, at one concentration (the size of the read-out at that concentration, not a potency): 4%
Compound 4: the middle estimate sits 16 percentage points above what was measured, within the range that was stated.
By their numbers in this assay, from the lowest: compound 4; then compounds 3 and 1 (each within the scatter of the next).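

The change from compound 2 to compound 4 cannot be read as a step in this assay, as compound 2 has no single number there. Nothing shown offers an explanation for the result of compound 4. The compounds shown leave open how swapping (tert-butoxycarbonyl)amino for hydroxy alters the read-out.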